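Thiophen-3-yl replacing 4-methylphenyl on an amide scaffold

The source may hold more compounds than are shown below. What is called first, only, known or untested is meant among the compounds shown, and "the series" means these compounds.

Measured so far:
compound 1, `Cc1ccc(-c2ccc(CCC(=O)N3CCCC3)cc2)cc1`, 33200 nM
compound 2, `O=C(CCCCCCc1cccs1)N1CCCC1`, 14100 nM

In an assay on HEK293 cells for inhibition of N-acylethanolamine-hydrolyzing acid amidase (Rattus norvegicus), read by LC-MS, with a stated time of 30 min (a higher number here means a weaker inhibitor, a lower number a stronger inhibitor), compound 1 gives 33200 nM, the highest of the two numbers seen. Going by the values given here, compound 2 gives 14100 nM, a lower number by a gap that lies beyond the usual scatter, but the two structures differ in more than one place, so the two values show only that compound 2 is the stronger inhibitor of the pair.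

Compound 3 `O=C(CCc1ccc(-c2ccsc2)cc1)N1CCCC1` takes one step from compound 1: thiophen-3-yl in place of 4-methylphenyl on an aromatic carbon. Among the compounds with values here, no measured pair shows this exact change, so its size must be guessed. Compound 2, which also carries a thiophene ring, gives 14100 nM, which hints at a lower number, though on a different chain. The step is expected to be modest, toward a lower number, possibly just beyond the scatter. Compound 3 is thus estimated at 20000 nM, within 7000 nM to 60000 nM, a step of a 1.7-fold lower number from compound 1 to compound 3 (0.22 log units; within the scatter).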

Compound 3, half-maximal inhibitory concentration: 2500 nM
Beside the measured number, compound 3's estimate is 8.0-fold (0.90 log units) above it; the measured number lies below the stated range.
By their numbers in this assay, from the lowest: compound 3; then compound 2; then compound 1.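

Replacing 4-methylphenyl with thiophen-3-yl, on an aromatic carbon para to a group of 9 heavy atoms, gives a 13-fold lower number from compound 1 to compound 3 (1.12 log units; beyond the scatter) in this assay. Going by these compounds alone, this is the first single-place change, and it shows that the group at this position can strongly shift the inhibition of the enzyme, which the earlier pair, differing in more than one place, could not show. Nothing measured here explains the gain.

As far as these compounds go, the step changes several things at once, swapping a six-membered carbon ring with its methyl for a five-membered ring containing sulfur, so it remains open whether the sulfur ring itself matters or whether removing the methyl would be enough, as a plain phenyl group at this position could show. Also open, from the compounds shown here alone, is how a thiophen-2-yl group or an amine at the same place would compare.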